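Hydroxyphenyl placement on a shared nitrile core

This account rests on a few compounds, and the source may have more. Where it says the series, first, only, none or still open, it means among the compounds named here.

Measured so far:
compound 1 `COc1cc2sc(Nc3cccc(O)c3)c(C#N)c2cc1OC` gives 11%
compound 2 `N#Cc1c(Nc2ccccc2O)sc2ccccc12` gives 19%

Both numbers come from a functional assay on HUVEC cells (Homo sapiens), read by fluorescence and microscopy, with a stated time of 6 h, tested at 10 uM; a higher number here means a weaker effect of the compound at the concentration tested, a lower number a stronger effect. In this assay compound 1 gives 11% and compound 2 gives 19%; the gap between these two lies within the usual scatter of repeated measurements, so neither stands apart from the other. Among the measured compounds shown here, no pair among the measured compounds differs in a single place, so no directly comparable step is available.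

Compound 3 `COc1cc2sc(Nc3ccc(O)cc3)c(C#N)c2cc1OC` is not yet measured. It is built from compound 1 with the same atoms joined differently: 4-hydroxyphenyl in place of 3-hydroxyphenyl on a nitrogen on an aromatic ring. For the measured compounds named here, for a change of this kind, with no comparable step on record, the expected step from compound 1 to compound 3 in this assay is none beyond the scatter, a number 3 percentage points higher from compound 1 to compound 3 (within the scatter). On that basis compound 3 is estimated at 14% in this assay, with a range from 4% to 35%.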

Compound 3, a percentage reported as activity, at one concentration (the size of the read-out at that concentration, not a potency): 0%
Compound 3: the middle estimate sits 14 percentage points above what was measured; measured number below the stated range.
By their numbers in this assay, from the lowest: compound 3; then compounds 1 and 2 (each within the scatter of the next).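

In this assay the swap of 3-hydroxyphenyl for 4-hydroxyphenyl on a nitrogen on an aromatic ring gives a number 11 percentage points lower from compound 1 to compound 3 (beyond the scatter) on an otherwise unchanged compound. The two groups have the same heavy atoms, ring and hydrogen-bond donor and acceptor counts, so this position responds to how the same atoms are joined, a point that compounds 1 and 2 could not show because they differ in more than one place. Nothing on hand bears on why the 4-hydroxyphenyl group gives the lower number.

Still open, as far as these compounds go, is whether the same swap would give a comparable step on the core of compound 2. The compounds shown also leave open how an amine or a carboxylic acid would compare with the hydroxyl group on the 4-hydroxyphenyl ring.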